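The compounds below may be only part of what the source reports. "The series", "measured", "known", "first", "only" and "open" are said of these compounds alone.

Measured compounds:
Compound 1, `c1ccc(/N=c2\ssnc2-c2ccccc2)cc1`: in a functional assay on MDA-MB-231 cells (Homo sapiens) for antiproliferative activity, read by MTT assay, with a stated time of 72 h (on this read-out higher numbers stand for weaker inhibition of growth and lower numbers for stronger inhibition of growth), compound 1 gives > 10000 nM, a limit of the assay.
Compound 2, `Fc1ccc(-c2nss/c2=N\c2ccccc2)cc1`: in this assay compound 2 gives > 10000 nM, a limit of the assay.
Compound 3, `S=c1ssnc1-c1ccccc1`: in this assay compound 3 gives > 10000 nM, a limit of the assay.

Compound 3 stands at the limit, as does every value shown here (the limit of > 10000 nM in this assay, at which 3 of the 3 values shown sit); no number for it is known, only that its growth inhibition on this read-out falls outside the range of the assay.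

The next compound, compound 4, `O=[N+]([O-])c1ccc(-c2nssc2=S)cc1`, differs from compound 3 by nitro in place of hydrogen on an aromatic carbon.

Among the compounds with values here, only one step between measured compounds can be compared, a step that the two limits leave unreadable from compound 1 to compound 2, and both of its ends sit at the limit, so its size is not readable. Within the data shown here, no measured step therefore bears on a nitro group, and the data give no guide to the direction or size of the change from compound 3 to compound 4 in this assay.

With all values shown at the limit, the expectation is that compound 4 also sits at or near the limit, the step that the limit leaves unreadable from compound 3 to compound 4 being expected to lie within the scatter. The estimate for compound 4 is 15000 nM, with a range from 4000 nM to 60000 nM.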

Compound 4, concentration for 50% growth inhibition: > 10000 nM
Compound 4: a limit, no number; the forecaster's own chance of this, stated with the estimate: 80%; the middle value is on the limit's open side.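

Compound 3 and compound 4 both stand at a limit, not a number, so no size can be read for nitro in place of hydrogen on an aromatic carbon: the limit of > 10000 nM in this assay, at which 4 of the 4 values shown sit. The compounds shown leave open whether any change on the shared core alters growth inhibition.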